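The source may hold more compounds than are shown below. What is called first, only, known or untested is meant among the compounds shown, and "the series" means these compounds.

Working notes on the series. The shared core is set out in compound 1 `CCOC(=O)c1cnc(C)nc1NN1C(=O)C=C(C)C1=O`, which carries a methyl on the aromatic carbon between two ring nitrogen atoms; in a functional assay on Jurkat cells for inhibition of nuclear factor NF-kappa-B complex (Homo sapiens) (a higher number here means a weaker inhibitor, a lower number a stronger inhibitor), compound 1 gives 16000 nM. Compound 2 `CCOC(=O)c1cnc(-c2cccs2)nc1NN1C(=O)C=C(C)C1=O` carries thiophen-2-yl at that carbon and in this assay compound 2 gives 20 nM. Compound 3 `CCOC(=O)c1cnc(-c2cc3ccccc3s2)nc1NN1C(=O)C=C(C)C1=O` carries 1-benzothiophen-2-yl there and in this assay compound 3 gives 4000 nM.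

Compound 2 holds the lowest number of the three: an 800-fold lower number from compound 1 to compound 2 (2.90 log units; beyond the scatter), and a 200-fold higher number from compound 2 to compound 3 (2.30 log units; beyond the scatter). Both steps are large and both change only the group on this one carbon.

Compound 4 `CCOC(=O)c1cnc(Oc2ccccc2)nc1NN1C(=O)C=C(C)C1=O` differs from compound 2 in the same place: phenoxy in place of thiophen-2-yl on an aromatic carbon. Among the measured compounds shown here, the steps that bear on this are an 800-fold lower number from compound 1 to compound 2 (2.90 log units; beyond the scatter) and a 200-fold higher number from compound 2 to compound 3 (2.30 log units; beyond the scatter); they show that the group on this carbon moves the numbers strongly in either direction, but no measured compound carries phenoxy or any group joined through oxygen, so the direction for compound 4 is not fixed by the data. Since compound 2 stands lowest and both measured neighbours lie well above it, a step upward beyond the scatter is expected, of about a 20-fold higher number from compound 2 to compound 4 (1.30 log units; beyond the scatter). Compound 4 is therefore estimated at 400 nM, with a wide range from 50 nM to 4000 nM.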

Compound 4, half-maximal inhibitory concentration: 15000 nM
Beside the measured number, compound 4's estimate is 38-fold (1.57 log units) below it; measured number above the stated range.
By their numbers in this assay, from the lowest: compound 2; then compound 3; then compounds 4 and 1 (each within the scatter of the next).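

Phenoxy takes away almost all of what thiophen-2-yl gained at this carbon (a 750-fold higher number from compound 2 to compound 4 (2.88 log units; beyond the scatter)), and in this assay it cannot be told apart from methyl (a 1.1-fold lower number from compound 1 to compound 4 (0.03 log units; within the scatter)), so a group with one aromatic ring on this carbon does not by itself give a low number. Compound 4 also lies modestly above the 1-benzothiophen-2-yl analogue (a 3.8-fold higher number from compound 3 to compound 4 (0.57 log units; beyond the scatter)), which leaves the thiophen-2-yl of compound 2 alone at the low end among the four groups, with compound 3 and compound 4 both carrying aromatic rings and neither coming near it. No measurement on these compounds accounts for these steps.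

Going by these compounds, what stays open is whether the link through oxygen or the six-membered ring separates compound 4 from compound 2, a question that a phenyl joined directly to this carbon, or an anilino group, would bear on. Also open, on these data alone, is how narrow the low number of compound 2 is, which furan-2-yl, thiophen-3-yl or a methyl-substituted thiophene at the same carbon would help to define.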